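The compounds below may be only part of what the source reports. "The series", "measured", "known", "first", "only" and "open" are said of these compounds alone.

In an ADME assay on the whole organism (Mus musculus, strain ICR(CD-1)), read by mass spectrometry, at a dose of 10 mg/kg by the oral route (a higher number here means that the compound lasts longer, a lower number that the compound disappears faster), compound 1 (`Cc1ccc(C(=O)Nc2cccc(C(F)(F)F)c2)cc1-c1ccc2c(-c3cnn(C)c3)n[nH]c2c1`) gives 3.26 h and compound 2 (`Cc1ccc(C(=O)Nc2cccc(C(F)(F)F)c2)cc1-c1ccc2c(-c3cnn(C4CC4)c3)n[nH]c2c1`) gives 5.71 h while compound 3 (`Cc1ccc(C(=O)Nc2cccc(C(F)(F)F)c2)cc1-c1ccc2c(-c3cnn(CC(C)O)c3)n[nH]c2c1`) gives 1.37 h as the lowest of the three numbers. Compound 4 (`Cc1ccc(C(=O)Nc2cccc(C(F)(F)F)c2)cc1-c1ccc2c(-c3cnn(C4CCN(C)CC4)c3)n[nH]c2c1`) carries 1-methylpiperidin-4-yl in place of 2-hydroxypropyl on an aromatic nitrogen. Two measured steps end at the 2-hydroxypropyl group (a 2.4-fold lower number from compound 1 to compound 3 (0.38 log units; beyond the scatter)) and (a 4.2-fold lower number from compound 2 to compound 3 (0.62 log units; beyond the scatter)), both modest and beyond the scatter. The remaining step (a 1.8-fold higher number from compound 1 to compound 2 (0.24 log units; within the scatter)) lies within the scatter. Among the compounds with values here, no measured compound carries 1-methylpiperidin-4-yl, so what that group itself does in this assay is unknown. A modest rise is nevertheless expected on leaving 2-hydroxypropyl, since compound 1 without that group holds 3.26 h against the lower number of compound 3. The estimated step is of that modest size (a 2.6-fold higher number from compound 3 to compound 4 (0.41 log units; beyond the scatter)). Compound 4 is expected at 3.5 h with a range from 1.6 h to 7.5 h as estimated here.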

Compound 4, mean residence time: 3.96 h
Estimate against measurement, compound 4: 1.1-fold (0.05 log units) below, within the range that was stated.
By their numbers in this assay, from the lowest: compound 3; then compounds 1, 4 and 2 (each within the scatter of the next).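

In this assay, the aromatic nitrogen of the five-membered ring accepts 1-methylpiperidin-4-yl, a six-membered non-aromatic ring with 1 hetero atom, with a 1.2-fold higher number from compound 1 to compound 4 (0.08 log units; within the scatter) and a 1.4-fold lower number from compound 2 to compound 4 (0.16 log units; within the scatter) both within the scatter, so methyl, cyclopropyl and 1-methylpiperidin-4-yl cannot be separated at this position. Against that, a 2.9-fold higher number from compound 3 to compound 4 (0.46 log units; beyond the scatter) lies beyond the scatter and leaves compound 3, the only one of the four compounds with a hydroxyl on this group, alone at the low end of the series. No data are at hand that explain this difference.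

Still open, from the compounds shown here alone, is whether the low number of compound 3 goes with the hydroxyl or with the open chain, which a plain propyl chain or a hydroxyl carried on a ring would separate. Equally open, going by these compounds, is what the ring nitrogen contributes, which a cyclohexyl ring or a piperidin-4-yl ring without the methyl group would address.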